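Aryl Amide Replaces Cyclohexyl Amide in mGlu5 Modulators

A few compounds are considered here, and "the series" means these few. Any claim that something is new, unique, unknown or untested is made for them only; others in the source may bear on it.

Measured compounds:
Compound 1, `O=C(C1CCC1)N1CCCC1c1nc(-c2cccc(F)c2)no1`, gives 1500 nM; 1500 nM (2 entries) in an in vitro functional assay on HEK293-A cells for positive allosteric modulation of metabotropic glutamate receptor 5 (Homo sapiens), read by fluorescence and calcium flux, with a stated time of 140 s; a higher number here means that more compound is needed for the effect, a lower number that less compound is needed.
Compound 2, `O=C(C1CCCCC1)N1CCCC1c1nc(-c2cccc(F)c2)no1`, gives 10000 nM in this assay.

Compound 2 has a single measured number in this assay; a second determination returned no single number. Against compound 1, which has two matching entries, compound 2 stands at the weaker end of the two values shown, though no step between them is computed here.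

Compound 3, `O=C(c1ccc(F)c(F)c1)N1CCCC1c1nc(-c2cccc(F)c2)no1`, is the next step from compound 2: 3,4-difluorophenyl in place of cyclohexyl on a carbonyl carbon. Compound 1 and compound 2 together show that the group on the carbonyl carbon matters, with the larger saturated ring giving the higher number. Among the measured compounds shown here, an aromatic ring with two fluorines is a different kind of group, and nothing among the measured compounds shows what such a group does. A gain over compound 2 seems more likely than a loss, but the uncertainty is wide.

For compound 3 an estimate of 3000 nM is expected in this assay, within a range of 500 nM to 15000 nM. The expected step is a 3.3-fold lower number from compound 2 to compound 3 (0.52 log units; beyond the scatter).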

Compound 3, half-maximal effective concentration: 3700 nM
Estimate against measurement, compound 3: 1.2-fold (0.09 log units) below; the range from low to high includes it.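

The result shows that the carbonyl carbon is not confined to saturated carbon rings: with 3,4-difluorophenyl in place of cyclohexyl, a 2.7-fold lower number from compound 2 to compound 3 (0.43 log units; beyond the scatter) in this assay. It also qualifies what the earlier pair suggested, that a larger group on this carbon gives a higher number, since 3,4-difluorophenyl has more heavy atoms than cyclohexyl, yet compound 3 goes against that pattern. The aromatic replacement does not settle the matter in its favour, however, as compound 3 at 3700 nM still has a higher printed value than compound 1 at 1500 nM; 1500 nM (2 entries), and no measurement offered here accounts for the change.

This single step replaces the saturated ring with an aromatic one and adds two fluorines at the same time, so the compounds shown cannot separate these two changes. Plain phenyl on the carbonyl carbon would speak to that question, while pyridyl or a cyclobutyl ring carrying fluorines would show whether the aromatic ring itself or the fluorines account for the step.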